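The source may report more compounds than this note shows. Statements on the series, on what has been measured and on what is new or still open speak of the compounds shown alone.

Measured so far:
- compound 1, `O=[N+]([O-])c1cn2c(n1)OC[C@@H](OCCOc1ccc(-c3ccc(OC(F)(F)F)cc3)cc1)C2`, in an ADME assay on microsomes from liver (Homo sapiens) for metabolic stability, read by LC-MS, with a stated time of 1 h, tested at 1 uM (a lower number here means that less of the compound is left, a higher number that more of the compound is left), gives 90%
- compound 2, `O=[N+]([O-])c1cn2c(n1)OC[C@@H](OC/C=C/c1ccc(OC(F)(F)F)cc1)C2`, in this assay gives 99%
- compound 3, `O=[N+]([O-])c1cn2c(n1)OC[C@@H](OC/C=C/c1ccc(-c3ccc(OC(F)(F)F)cc3)cc1)C2`, in this assay gives 100%

Compound 3 and compound 2 share a core and differ in one place: trifluoromethoxy in place of 4-(trifluoromethoxy)phenyl on an aromatic carbon. This change moved the result by a number 1 percentage points lower from compound 3 to compound 2 (within the scatter), so the two values sit at the same level within the usual scatter. Compound 1 has a different core, and the difference between the two cores is not broken down here; compound 1 does, however, carry the same 4-(trifluoromethoxy)phenyl group as compound 3. Compound 4, `O=[N+]([O-])c1cn2c(n1)OC[C@@H](OCCOc1ccc(OC(F)(F)F)cc1)C2`, is not yet measured. It relates to compound 1 exactly as compound 2 relates to compound 3: trifluoromethoxy in place of 4-(trifluoromethoxy)phenyl on an aromatic carbon. The place of the change is the same in both pairs, so this is the same change made on a second core. Because the earlier step was a number 1 percentage points lower from compound 3 to compound 2 (within the scatter), the expectation for compound 4 is a step of about no change at the digits printed from compound 1 to compound 4 (within the scatter) from compound 1 in this assay. Compound 4 is therefore expected to give 90%, estimated between 76% and 100%.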

Compound 4, percent of the compound remaining in the Homo sapiens assay: 85%
The estimate for compound 4 lay 5 percentage points above the measured number, within the range that was stated.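

In the Homo sapiens assay the new step is a number 5 percentage points lower from compound 1 to compound 4 (within the scatter), and replacing 4-(trifluoromethoxy)phenyl with trifluoromethoxy gives no visible difference between the two cores: the same change on two cores in the Homo sapiens assay, a number 1 percentage points lower (within the scatter) from compound 3 to compound 2 and a number 5 percentage points lower (within the scatter) from compound 1 to compound 4, 4 percentage points apart, within the scatter of two such steps In a physicochemical assay for solubility, read by HPLC, at pH 7 (a higher number here means a more soluble compound, a lower number a less soluble compound), compound 1 gives 0.68 ug/mL and compound 4 gives 50 ug/mL. In the physicochemical assay the same change on the core of compound 1 goes with a far larger shift: the measured solubility of compound 1, 0.68 ug/mL, and of compound 4, 50 ug/mL, a 74-fold higher number (1.87 log units; beyond the scatter) The compounds shown give this solubility step on one core only, so they do not show that it carries over to the other core, and two pairs on two cores set no rule for any further core.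

On these data alone, it remains open how either read-out would respond if an amine or a carboxylic acid took the place of trifluoromethoxy on the aromatic carbon. A longer chain in the side arm is also untested among the compounds shown, so its effect on either read-out cannot be told from them.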